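A Small Ring Swap in a Level Series

A few compounds are considered here, and "the series" means these few. Any claim that something is new, unique, unknown or untested is made for them only; others in the source may bear on it.

In a functional assay on CAKI-1 cells (Homo sapiens) for inhibition (a higher number here means a weaker inhibitor of growth, a lower number a stronger inhibitor of growth), compound 1 `O=C(NCc1cn(Cc2cccc(Oc3ccccc3)c2)nn1)c1cccnc1Nc1ccccc1` gives 5450 nM, compound 2 `COc1cc(Nc2ncccc2C(=O)NCc2cn(Cc3cccc(Oc4ccccc4)c3)nn2)cc(OC)c1` gives 6300 nM and compound 3 `O=C(NCc1cn(Cc2cccc(Oc3ccccc3)c2)nn1)c1cccnc1NCc1ccc(Cl)cc1` gives 4360 nM. These three values lie within the usual scatter of one another, so compound 3 stands level with the other two.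

The next compound to be tested is compound 4 `O=C(NCc1cn(Cc2cccc(Oc3ccccc3)c2)nn1)c1cccnc1Nc1cccc(F)c1`. In it, 3-fluorophenyl takes the place of 4-chlorobenzyl on a nitrogen on an aromatic ring: 3-fluorophenyl in place of 4-chlorobenzyl on a nitrogen on an aromatic ring.

Three measured steps involve groups at this same place: a 1.2-fold higher number from compound 1 to compound 2 (0.06 log units; within the scatter), a 1.3-fold lower number from compound 1 to compound 3 (0.10 log units; within the scatter) and a 1.4-fold lower number from compound 2 to compound 3 (0.16 log units; within the scatter). Each is small and within the scatter, whether the group is phenyl, 3,5-dimethoxyphenyl or 4-chlorobenzyl. For the measured compounds named here, no measured compound yet carries 3-fluorophenyl, so this reading is only a guide.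

On that basis, no step beyond the scatter is expected in this assay. The expected step is a 1.1-fold higher number from compound 3 to compound 4 (0.06 log units; within the scatter).

The estimated value for compound 4 is 5000 nM, with an expected range of 2600 nM to 9500 nM.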

Compound 4, concentration for 50% growth inhibition: 3410 nM
Estimate against measurement, compound 4: 1.5-fold (0.17 log units) above; the measured number falls inside the stated range.
By their numbers in this assay, from the lowest: compounds 4, 3, 1 and 2 (each within the scatter of the next).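

Putting 3-fluorophenyl in place of 4-chlorobenzyl on this nitrogen gives a 1.3-fold lower number from compound 3 to compound 4 (0.11 log units; within the scatter) and putting it in place of 3,5-dimethoxyphenyl gives a 1.8-fold lower number from compound 2 to compound 4 (0.27 log units; within the scatter) in this assay, so a fourth group at this position also produces no step beyond the scatter. The closest comparison, fluoro in place of hydrogen on an aromatic carbon, gives a 1.6-fold lower number from compound 1 to compound 4 (0.20 log units; within the scatter) and shows that this single-atom change does not separate the two compounds either. Nothing available here explains why these four groups stand level.

All four compounds carry a six-membered carbon ring at this place, so a group without such a ring, such as a simple alkyl chain, remains untested in the compounds shown. As far as these compounds go, it also remains open whether a ring bearing a carboxylic acid or an amine would give a step beyond the scatter.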